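The source may hold more compounds than are shown below. What is called first, only, known or untested is meant among the compounds shown, and "the series" means these compounds.

Working notes on the series. Compound 1 `COc1cc2c(Oc3ccc(NC(=O)c4cc(-c5ccccc5)nc5ccccc45)cc3F)ccnc2cc1OCCCN1CCCCC1` is measured in a functional assay on MKN-45 cells (Homo sapiens) for cytotoxicity, read by MTT assay, with a stated time of 72 h (a lower number here means a stronger inhibitor, a higher number a weaker inhibitor), where compound 1 gives 15 nM. Compound 2 `COc1cc2c(Oc3ccc(NC(=O)c4cc(-c5cccc(Cl)c5)nc5ccccc45)cc3F)ccnc2cc1OCCCN1CCCCC1` differs from compound 1 by chloro in place of hydrogen on an aromatic carbon. In this assay compound 2 gives 11 nM, and the step of a 1.4-fold lower number from compound 1 to compound 2 (0.13 log units; within the scatter) stays within the scatter, so the two values cannot be ordered. Compound 3 `COc1cc2c(Oc3ccc(NC(=O)c4cc(-c5ccccc5)nc5ccc(F)cc45)cc3F)ccnc2cc1OCCCN1CCCC1` is built on a different core, and the difference between the core of compound 1 and the core of compound 3 is not broken down here. In this assay compound 3 gives 110 nM, the highest of the three numbers, with the gaps to compound 1 and to compound 2 both beyond the scatter.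

Compound 4 `COc1cc2c(Oc3ccc(NC(=O)c4cc(-c5cccc(Cl)c5)nc5ccc(F)cc45)cc3F)ccnc2cc1OCCCN1CCCC1` is not yet measured. It differs from compound 3 by chloro in place of hydrogen on an aromatic carbon, the same change as that between compound 1 and compound 2, at a place described in the same terms. For the measured compounds named here, the one measured instance of this change, the step of a 1.4-fold lower number from compound 1 to compound 2 (0.13 log units; within the scatter), lies within the scatter. A single instance on another core is thin footing, but nothing measured points to a larger effect. For compound 4 in this assay a step of a 1.4-fold lower number from compound 3 to compound 4 (0.14 log units; within the scatter) is expected, because the step of a 1.4-fold lower number from compound 1 to compound 2 (0.13 log units; within the scatter) was small. The expectation for compound 4 therefore starts from the value of compound 3, 110 nM, and moves little. The estimate for compound 4 is 80 nM, with a likely range from 35 nM to 180 nM.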

Compound 4, half-maximal inhibitory concentration: 67 nM
Estimate against measurement, compound 4: 1.2-fold (0.08 log units) above; the range from low to high includes it.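

In this assay, the change from phenyl to 3-chlorophenyl on the core of compound 3 gives a 1.6-fold lower number from compound 3 to compound 4 (0.22 log units; within the scatter), so the two values cannot be ordered. The change reads alike on the two cores, and the size of its step does not separate them: the same change on two cores in this assay, a 1.4-fold lower number (0.13 log units; within the scatter) from compound 1 to compound 2 and a 1.6-fold lower number (0.22 log units; within the scatter) from compound 3 to compound 4, 1.2-fold (0.08 log units) apart, within the scatter of two such steps This shows that in the two available cases the change carries from one core to the other without a step beyond the scatter, but since neither step leaves the scatter, it does not show that chloro in this place improves the cytotoxicity read-out on either core, and two cores are too few to support a rule for the whole series.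

The compounds shown leave open whether a group other than chloro on an aromatic carbon at this place, such as bromo, methoxy, trifluoromethyl, a nitrile, an amine or a carboxylic acid, would give a step beyond the scatter on either core. They also leave open whether a second chloro on the same ring would do so, and whether the close agreement of the two steps would hold on any further core.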